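A few compounds are considered here, and "the series" means these few. Any claim that something is new, unique, unknown or untested is made for them only; others in the source may bear on it.

Measured compounds:
compound 1 `Cc1nc2c(C[S+]([O-])c3ccccc3)cccn2c1C` — 42%
compound 2 `CSCc1c(C)nc2c(OCc3ccccc3)cccn12` — 29%
compound 3 `Cc1nc2c(OCc3ccccc3)cccn2c1C[S+](C)[O-]` — 0%

In a functional assay on the whole organism with Rattus norvegicus as the target, with a stated time of 4 h, at a dose of 40 mg/kg by the intraperitoneal route (on this read-out higher numbers stand for more inhibition at the one dose given (going by the name of the read-out) and lower numbers for less inhibition), compound 3 gives 0%, the lowest of the three numbers; compound 2 sits a number 29 percentage points lower from compound 2 to compound 3 (beyond the scatter), beyond the scatter, and the gap to compound 1 is also beyond the scatter. That one step, from compound 2 to compound 3, is the only one in the series that touches the saturated chain carbon bound to an aromatic carbon, and it runs downward when a group of 3 heavy atoms (1 carbon, 1 oxygen, 1 sulfur; no ring) replaces a group of 2 heavy atoms (1 carbon, 1 sulfur; no ring).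

Compound 4 `Cc1nc2c(OCc3ccccc3)cccn2c1COC(=O)C(C)(C)C` is not yet measured. It differs from compound 3 as follows: a group of 7 heavy atoms (5 carbon, 2 oxygen; no ring) in place of a group of 3 heavy atoms (1 carbon, 1 oxygen, 1 sulfur; no ring), on a saturated chain carbon bound to an aromatic carbon. Within the data shown here, no measured pair shows a ((tert-butyl)carbonyl)oxy group at this place, so the step from compound 2 to compound 3 bears only indirectly: it shows that this position is sensitive, and that compound 3 is the floor from which the new group departs. Since compound 3 is already at zero, a further fall cannot be read; a return toward the level of compound 2 is possible but unsupported. The expectation for compound 4 is therefore a modest rise, a number 18 percentage points higher from compound 3 to compound 4 (beyond the scatter), with wide uncertainty. Compound 4 is estimated at 18%, within 0% to 45%.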

Compound 4, a percentage reported as inhibition, in the whole organism at one dose (the size of the read-out at that dose, not a potency): 48%
Compound 4: the middle estimate sits 30 percentage points below what was measured; the measured number lies above the stated range.
By their numbers in this assay, from the lowest: compound 3; then compound 2; then compounds 1 and 4 (each within the scatter of the next).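

In this assay the saturated chain carbon bound to an aromatic carbon is not a place where change only costs: ((tert-butyl)carbonyl)oxy gives a number 48 percentage points higher from compound 3 to compound 4 (beyond the scatter), and set against methylsulfanyl it gives a number 19 percentage points higher from compound 2 to compound 4 (beyond the scatter). Among the three compounds that differ only at this place, the order from the lowest is now compound 3, compound 2, compound 4, so steps at this place run both down and up, and the group at the top of that order carries no sulfur, which means sulfur in the group is not required for the read-out to rise at this place. No measurement at hand accounts for the rise.

The compounds shown do not separate the contribution of the tert-butyl part from that of the carbonyl-oxygen link, and a hydroxyl, an acetyloxy group, an amine or a carboxylic acid at the same place would be needed to tell which part of the new group goes with the higher number. Also open, from the compounds shown here alone, is whether the order of these three compounds would hold at other doses or times, as each number here comes from one dose and one stated time.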